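The compounds below may be only part of what the source reports. "The series", "measured", "known", "first", "only" and "open" are said of these compounds alone.

Measured in a physicochemical assay for solubility; a lower number here means a less soluble compound, a higher number a more soluble compound:
Compound 1 `COc1ccc(C(=O)Nc2ccc([N+](=O)[O-])cc2Cl)c(O)c1`: < 1 ug/mL (a limit)
Compound 2 `N#Cc1ccc(NC(=O)c2cc(Cl)ccc2O)c(Cl)c1`: < 1 ug/mL (a limit)
Compound 3 `O=C(Nc1ccc(F)cc1F)c1cc(Cl)ccc1O`: 1 ug/mL (a number)

Compound 2 has no numerical value in this assay, only the limit < 1 ug/mL. It shares that position with one other compound, and the set as a whole sits at the edge of what can be read: the limit of < 1 ug/mL in this assay, at which 2 of the 3 values shown sit. Among the measured compounds shown here, the one number comes from compound 3, at 1 ug/mL.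

Compound 4 `O=C(Nc1ccc(C(F)(F)F)cc1Cl)c1cc(Cl)ccc1O` differs from compound 2 by carrying trifluoromethyl in place of cyano on an aromatic carbon, meta to a chloro group and para to a large group: trifluoromethyl in place of cyano on an aromatic carbon. For the measured compounds named here, no measured pair shows this change on its own, so the expectation rests on the values alone. Given that compound 3 reaches only 1 ug/mL, no step beyond the scatter is expected. For compound 4, a report of a limit is likely.

The estimated change is a step that the limit leaves unreadable from compound 2 to compound 4, which is expected to stay within the scatter. The estimate for compound 4 is 0.7 ug/mL, with an expected range of 0.3 ug/mL to 1.5 ug/mL.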

Compound 4, solubility: < 1 ug/mL
Compound 4: no number, only a limit; the forecaster's own chance of this, stated with the estimate: 75%; the middle value lies beyond the limit too.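

Compound 2 and compound 4 are both reported only as limits in this assay, and the step between them cannot be read. The compounds shown leave open whether trifluoromethyl in place of cyano on an aromatic carbon changes anything in this assay, as the set still sits at the edge of what can be read: the limit of < 1 ug/mL in this assay, at which 3 of the 4 values shown sit.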